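Adding a methyl to the double bond of two diaryl ethylenes

This account rests on a few compounds, and the source may have more. Where it says the series, first, only, none or still open, it means among the compounds named here.

Compound 1 `C=C(c1cc(OC)cc(OC)c1)c1ccc(OC)c(OC)c1` and compound 3 `CC=C(c1cc(OC)cc(OC)c1)c1ccc(OC)c(OC)c1` share a core and differ by methyl in place of hydrogen on a double-bonded chain carbon bound to a double-bonded chain carbon. In a functional assay on HCT-116 cells (Homo sapiens) for cytotoxicity, read by scintillation counting and thymidine incorporation, with a stated time of 72 h (a higher number here means a weaker inhibitor, a lower number a stronger inhibitor), compound 1 reaches only a limit of the measurement, > 10000 nM. Compound 3 gives 480 nM in this assay, so the change made an at least 20-fold lower number from compound 1 to compound 3 (1.31 log units; beyond the scatter). Compound 2 `C=C(c1ccc(OC)c(N)c1)c1ccc(OC)c(OCC)c1` carries a different core; the difference between the two cores is not broken down here. In this assay compound 2 gives 38 nM. Compound 4 `CC=C(c1ccc(OC)c(N)c1)c1ccc(OC)c(OCC)c1` stands to compound 2 as compound 3 stands to compound 1, differing by methyl in place of hydrogen on a double-bonded chain carbon bound to a double-bonded chain carbon. Going by these compounds, since compound 1 sits at the limit of > 10000 nM in this assay, at which 1 of the 3 values shown sits, the true size of the first step is unknown, and compound 2 already gives a low number, so a smaller step is expected, a 2.1-fold lower number from compound 2 to compound 4 (0.32 log units; beyond the scatter). Compound 4 is estimated at 18 nM, between 4 nM and 90 nM.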

Compound 4, half-maximal inhibitory concentration: 110 nM
Beside the measured number, compound 4's estimate is 6.1-fold (0.79 log units) below it; measured number above the stated range.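

In this assay, the methyl gives a 2.9-fold higher number from compound 2 to compound 4 (0.46 log units; beyond the scatter), so the change that lowered the number on the core of compound 1 raises it on the core of compound 2. The same change therefore does not carry over between these two cores, even in direction: the same change on two cores in this assay, an at least 20-fold lower number (1.31 log units; beyond the scatter) from compound 1 to compound 3 and a 2.9-fold higher number (0.46 log units; beyond the scatter) from compound 2 to compound 4, at least 60-fold (1.78 log units) apart, beyond the scatter of two such steps These two pairs show that the outcome of adding the methyl depends on the core, but not which difference between the cores decides it.

Going by these compounds, it remains open how a longer chain, such as propyl, on that same carbon would behave on each core. Also open, on these data alone, is whether a core carrying only some of the differences between the two would follow compound 3 or compound 4.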